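Swapping a Fluoro for an Isopropyl on the Aniline Ring

A few compounds are considered here, and "the series" means these few. Any claim that something is new, unique, unknown or untested is made for them only; others in the source may bear on it.

Measured so far:
compound 1 `Fc1cccc(Nc2nc(-c3ccncc3)cs2)c1`: 40700 nM
compound 2 `C#Cc1cnccc1-c1csc(Nc2cccc(C)c2)n1`: 1380 nM
compound 3 `Cc1cccc(Nc2nc(-c3ccncc3C#CCN3CCN(C)CC3)cs2)c1`: 2600 nM; 2630 nM (2 entries)

In a functional assay on RCC4 cells (Homo sapiens) for inhibition, read by XTT assay, with a stated time of 4 days (on this read-out higher numbers stand for weaker inhibition and lower numbers for stronger inhibition), compound 1 gives the highest of the two single numbers, and compound 2 sits far lower, beyond the usual scatter. Compound 3 has two entries close together (the several entries of compound 3 in this assay, 2600 nM; 2630 nM (2 entries)). Compound 4 `CC(C)c1cccc(Nc2nc(-c3ccncc3)cs2)c1` differs from compound 1 in one place: isopropyl in place of fluoro on an aromatic carbon. Within the data shown here, no measured pair shows this exact change, so the direction of the step is uncertain. A modest move toward a lower number seems plausible, but a step within the scatter is equally possible. The expected step from compound 1 to compound 4 is a 2.7-fold lower number from compound 1 to compound 4 (0.43 log units; beyond the scatter), and compound 4 is estimated at 15000 nM, ranging from 3000 nM to 60000 nM.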

Compound 4, half-maximal inhibitory concentration: 17400 nM
The estimate for compound 4 lay 1.2-fold (0.06 log units) below the measured number; measured number inside the range.
By their numbers in this assay, from the lowest: compound 2; then compound 4; then compound 1.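

In this assay, among these compounds, this is the first step between compounds that differ in one place. Isopropyl in place of fluoro, on an aromatic carbon meta to a large group, gives a 2.3-fold lower number from compound 1 to compound 4 (0.37 log units; beyond the scatter), so this position accepts the larger group with a modest gain in inhibition. Nothing measured here explains the step.

As far as these compounds go, on the core of compound 1, only these two groups can be compared at this position, so any link between group size and inhibition remains open. How an amine or a carboxylic acid would behave there is also unknown.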